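Adding a Methyl to the Smallest Side Chain

The compounds below may be only part of what the source reports. "The series", "measured", "known", "first", "only" and "open" are said of these compounds alone.

Three compounds share one core and differ only in the acid-bearing side chain. In an ADME assay on cells (Hepatocyte, Mus musculus) for metabolic stability, read by LC-MS, with a stated time of 180 min, tested at 1 uM (a lower number here means slower removal, a higher number faster removal of the compound), compound 1 `CCC(C(=O)O)c1nn(Cc2cn3cc(OCC4CC4)c(Cl)cc3n2)c2ccccc2c1=O` gives 155 mL/min/kg, compound 2 `CC(C)(C(=O)O)c1nn(Cc2cn3cc(OCC4CC4)c(Cl)cc3n2)c2ccccc2c1=O` gives 317 mL/min/kg, and compound 3 `O=C(O)Cc1nn(Cc2cn3cc(OCC4CC4)c(Cl)cc3n2)c2ccccc2c1=O` gives 30 mL/min/kg, the lowest of the three; its nearest neighbour is compound 1, and the gap is shown by a 5.2-fold lower number from compound 1 to compound 3 (0.71 log units; beyond the scatter), while the step of an 11-fold lower number from compound 2 to compound 3 (1.02 log units; beyond the scatter) is larger still. Compound 4 `C[C@H](C(=O)O)c1nn(Cc2cn3cc(OCC4CC4)c(Cl)cc3n2)c2ccccc2c1=O` differs from compound 3 by methyl in place of hydrogen on a saturated chain carbon bound to an aromatic carbon and a carbonyl carbon. Within the data shown here, the steps that bear on this change run the other way: a 5.2-fold lower number from compound 1 to compound 3 (0.71 log units; beyond the scatter) and an 11-fold lower number from compound 2 to compound 3 (1.02 log units; beyond the scatter) both show that removing carbon from this position lowers the number, and a 2.0-fold higher number from compound 1 to compound 2 (0.31 log units; beyond the scatter) shows that adding carbon raises it. A single methyl sits between the unbranched chain of compound 3 and the two carbons of compound 1, so compound 4 is expected to show a rise of about a 3.0-fold higher number from compound 3 to compound 4 (0.48 log units; beyond the scatter) in this assay, beyond the scatter. The estimate for compound 4 is 90 mL/min/kg, with a range from 40 mL/min/kg to 200 mL/min/kg.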

Compound 4, clearance: 33.3 mL/min/kg
Beside the measured number, compound 4's estimate is 2.7-fold (0.43 log units) above it; the measured number lies below the stated range.
By their numbers in this assay, from the lowest: compounds 3 and 4 (each within the scatter of the next); then compound 1; then compound 2.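

In this assay, the first methyl on this saturated chain carbon brings no change beyond the scatter, with a 1.1-fold higher number from compound 3 to compound 4 (0.05 log units; within the scatter) for carboxymethyl to 1-carboxyethyl. The clear steps appear only once more carbon is present, as shown by a 4.7-fold lower number from compound 1 to compound 4 (0.67 log units; beyond the scatter) and by a 9.5-fold lower number from compound 2 to compound 4 (0.98 log units; beyond the scatter) so, among these four compounds, the number does not follow the count of added carbon evenly. Nothing measured here gives the reason for this.

The compounds shown leave open what a hydroxyl group or an amine on this same carbon would do, and whether a longer unbranched chain would continue the trend seen with the 1-carboxypropyl group. They also leave open whether the mirror-image form of compound 4 would give a similar number.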